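The source may report more compounds than this note shows. Statements on the series, on what has been measured and on what is new or still open speak of the compounds shown alone.

Measured compounds in the series:

compound 1, `COC(=O)c1cc(Cl)ccc1OC(=O)COc1cc(O)c2c(=O)cc(-c3ccccc3)oc2c1`, 3740 nM
compound 2, `COC(=O)c1c(Br)cc(Br)cc1OC(=O)COc1cc(O)c2c(=O)cc(-c3ccccc3)oc2c1`, 45700 nM
compound 3, `COC(=O)c1c(Cl)cc(Cl)cc1OC(=O)COc1cc(O)c2c(=O)cc(-c3ccccc3)oc2c1`, 43600 nM

All three were run in a functional assay on cells (T-cell, Mus musculus, strain BALB/c) for inhibition, read by MTT assay, with a stated time of 72 h; a lower number here means a stronger inhibitor, a higher number a weaker inhibitor. Compound 1 gives the lowest number of the three, 3740 nM. Its nearest neighbour is compound 3 at 43600 nM, a gap beyond the scatter, and compound 2 at 45700 nM sits about as far away; both dihalogenated esters are clearly weaker than compound 1 on these numbers. Going by the values given here, no pair among the three differs in one place only, so no single step can be read from them.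

Compound 4, `COC(=O)c1cccc(C)c1OC(=O)COc1cc(O)c2c(=O)cc(-c3ccccc3)oc2c1`, has not yet been measured. Relative to compound 1 the change is a group of 11 heavy atoms (9 carbon, 2 oxygen; one six-membered aromatic ring of carbon only) in place of a group of 11 heavy atoms (8 carbon, 2 oxygen, 1 chlorine; one six-membered aromatic ring of carbon only), on an oxygen next to a carbonyl group. The leaving 4-chloro-2-(methoxycarbonyl)phenyl group carries a chlorine; the entering group carries none. Among the compounds with values here, no measured step tests this change, so the expectation rests on compound 1 alone. Compound 4 is expected to stay close to compound 1, with a step of a 1.3-fold higher number from compound 1 to compound 4 (0.13 log units; within the scatter) that is likely within or only just beyond the scatter, tending if anything toward a higher number. The estimate for compound 4 is 5000 nM, in the range 1500 nM to 20000 nM.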

Compound 4, half-maximal inhibitory concentration: 39100 nM
Compound 4: middle estimate off by 7.8-fold (0.89 log units), on the low side, and the stated range ends below it.
By their numbers in this assay, from the lowest: compound 1; then compounds 4, 3 and 2 (each within the scatter of the next).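

In this assay, going by these compounds alone, exchanging the 4-chloro-2-(methoxycarbonyl)phenyl group on the oxygen next to a carbonyl group for the chlorine-free group of compound 4 gives a 10-fold higher number from compound 1 to compound 4 (1.02 log units; beyond the scatter) as the only single-place step. The heavy-atom count and the one six-membered aromatic ring stay the same across this exchange, yet the step is large, so this position does not accept the change freely. No measurement of any property accompanies this step, and its size stands without an explanation.

As far as these compounds go, the exchange removes chlorine and brings in carbon in a single step, so the share of each remains open; groups carrying fluorine or methoxy in place of that chlorine would separate them. Also open, from the compounds shown here alone, is how a carboxylic acid in place of the methoxycarbonyl group would read in this assay on the same core.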